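Difluorophenyl isomer of compound 1 on the sulfonyl sulfur

A few compounds are considered here, and "the series" means these few. Any claim that something is new, unique, unknown or untested is made for them only; others in the source may bear on it.

Among the measured compounds shown here, compound 1 `CC1CCN(c2c(S(=O)(=O)c3ccc(F)c(F)c3)cnc3c(F)cccc23)CC1` gives the highest of the two numbers so far in an assay on isolated protein for displacement of a labelled ligand from metabotropic glutamate receptor 5 (Homo sapiens), with a stated time of 60 min, tested at 1 uM (a higher number here means more inhibition at the concentration tested (going by the name of the read-out), a lower number less inhibition), where compound 1 reaches 93%. For the measured compounds named here, the only other compound measured, compound 2 `CCN(CC)c1c(S(=O)(=O)c2ccc(C)cc2)cnc2ccccc12`, gives 78.3% in this assay, a gap from compound 1 that lies beyond the scatter. Compound 3 `CC1CCN(c2c(S(=O)(=O)c3cc(F)cc(F)c3)cnc3c(F)cccc23)CC1` has the same atoms as compound 1 joined differently: 3,5-difluorophenyl in place of 3,4-difluorophenyl on a sulfonyl sulfur. Going by the values given here, no measured pair shows a change of this kind, so its size is not known from the data at hand. Little room remains upward because compound 1 already gives 93% in this assay. The expected step is therefore a number 7 percentage points lower from compound 1 to compound 3 (within the scatter), a small loss within the scatter, rather than a gain. Compound 3 is estimated to give 86% in this assay, with a range from 65% to 97%.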

Compound 3, a percentage reported as inhibition, at one concentration (the size of the read-out at that concentration, not a potency): 9%
For compound 3 the middle estimate is 77 percentage points above the measured one, and the stated range ends above it.
By their numbers in this assay, from the lowest: compound 3; then compound 2; then compound 1.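

In this assay, 3,5-difluorophenyl in place of 3,4-difluorophenyl on a sulfonyl sulfur gives a number 84 percentage points lower from compound 1 to compound 3 (beyond the scatter). This position is therefore not indifferent to how the two fluorines are arranged: the same atoms, joined differently, separate a high read-out from a low one, which compound 1 and compound 2 alone could not show. Nothing at hand bears on why these two isomers part so widely.

On these data alone, it remains open whether the loss follows from the fluorine that leaves or the one that enters, a question that 3-fluorophenyl and 4-fluorophenyl on the same sulfur would help to settle. As far as these compounds go, it is also open whether the same isomer step holds when the 4-methylpiperidine of compound 1 is replaced by a morpholine.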